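Swapping the amide aryl group on a shared benzothiophene-free core

A few compounds are considered here, and "the series" means these few. Any claim that something is new, unique, unknown or untested is made for them only; others in the source may bear on it.

Measured so far:
compound 2, `CCOC(=O)c1sc2ccc(N)cc2c1NC(=O)c1ccc(OC)cc1`: > 50000 nM
compound 1, `CCOC(=O)c1sc2ccc(NCc3c[nH]cn3)cc2c1NC(=O)c1ccc(F)c(Cl)c1`: 10700 nM

Compound 2 `CCOC(=O)c1sc2ccc(N)cc2c1NC(=O)c1ccc(OC)cc1` gives no number in a functional assay on HeLa cells (Homo sapiens) for antiproliferative activity, read by MTT assay, with a stated time of 48 h; a higher number here means a weaker inhibitor of growth, a lower number a stronger inhibitor of growth; it sits at the limit of > 50000 nM in this assay, at which 1 of the 2 values shown sits, a limit of the assay. Compound 3 `CCOC(=O)c1sc2ccc(N)cc2c1NC(=O)c1ccc(F)c(Cl)c1` differs from compound 2 by 3-chloro-4-fluorophenyl in place of 4-methoxyphenyl on a carbonyl carbon. Compound 1 `CCOC(=O)c1sc2ccc(NCc3c[nH]cn3)cc2c1NC(=O)c1ccc(F)c(Cl)c1`, which carries the same 3-chloro-4-fluorophenyl group but a different substituent on the core, gives 10700 nM in this assay. On that basis compound 3 is expected to gain potency over the limit. The expected step of an at least 2.0-fold lower number from compound 2 to compound 3 (0.30 log units; that floor lies within the scatter) is an estimate. Compound 3 is estimated at 25000 nM, with a range from 8000 nM to 60000 nM.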

Compound 3, concentration for 50% growth inhibition: 12300 nM
Compound 3: middle estimate off by 2.0-fold (0.31 log units), on the high side; low and high end bracket the measured number.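

In this assay, 3-chloro-4-fluorophenyl in place of 4-methoxyphenyl on a carbonyl carbon gives an at least 4.0-fold lower number from compound 2 to compound 3 (0.60 log units; beyond the scatter), so the amide aryl group matters at this position. Going by these compounds, the true size of that step stays unknown, since compound 2 stands at a limit: the limit of > 50000 nM in this assay, at which 1 of the 3 values shown sits. Hydrogen in place of (1H-imidazol-4-yl)methyl on the core nitrogen gives a 1.1-fold higher number from compound 1 to compound 3 (0.06 log units; within the scatter), so that substituent makes no measurable difference with this aryl group. On these data alone, it remains open whether a phenyl group carrying only chlorine or only fluorine would hold the gain.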